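The source may report more compounds than this note shows. Statements on the series, on what has been measured and on what is new or still open speak of the compounds shown alone.

Compound 2 `COc1ccc(-c2nc3ccccc3s2)cc1NC(=O)c1cnccc1Cl` is a close relative of compound 1 `Cc1ccc(-c2nc3ccccc3s2)cc1NC(=O)c1cnccc1Cl`, with a methoxy in place of a methyl on an aromatic carbon. In an ADME assay on BJ cells (Homo sapiens) for inhibition, with a stated time of 72 h (a higher number here means that more compound is needed for the effect, a lower number that less compound is needed), compound 1 gives only a limit of the assay, > 25000 nM. In this assay compound 2 likewise gives only a limit, > 25000 nM. The step that the two limits leave unreadable from compound 1 to compound 2 therefore cannot be read. Compound 3 `COc1ccc(-c2nc3ccccc3o2)cc1NC(=O)c1cnccc1Cl` carries 1,3-benzoxazol-2-yl in place of 1,3-benzothiazol-2-yl on an aromatic carbon. For the measured compounds named here, no measured step bears on this change; the only evidence is the limit of > 25000 nM in this assay, at which 2 of the 2 values shown sit. Compound 3 is estimated at 30000 nM, with a range from 10000 nM to 100000 nM. The implied step that the limit leaves unreadable from compound 2 to compound 3 is expected to be none beyond the scatter.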

Compound 3, half-maximal effective concentration in the BJ assay: > 25000 nM
Compound 3 gave a limit, no number; the forecaster's own chance of this, stated with the estimate: 80%; the middle value does not contradict the limit.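

In the BJ assay compound 2 gives > 25000 nM as a limit of the assay. In the BJ assay compound 3 likewise gives > 25000 nM as a limit of the assay, so the step between compound 2 and compound 3 cannot be read. The compounds shown leave open whether 1,3-benzoxazol-2-yl in place of 1,3-benzothiazol-2-yl changes the concentration needed at all. In a physicochemical assay for solubility, in phosphate buffer, measured as kinetic solubility, with a stated time of 18 h, at pH 7.4 (a lower number here means a less soluble compound, a higher number a more soluble compound), compound 2 gives 340 nM and compound 3 gives 1680 nM as measured values.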